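The source may hold more compounds than are shown below. What is called first, only, known or untested is meant among the compounds shown, and "the series" means these compounds.

Two compounds here share one core and differ in the group on a single aromatic carbon. Compound 1 `O=C(NO)c1cccc(OCc2ccc(-c3ccc(Cl)cc3)cc2)c1` carries a 4-chlorophenyl there, and in an assay on isolated protein for inhibition of sphingomyelin phosphodiesterase (Homo sapiens), read by fluorescence, with a stated time of 30 min (a lower number here means a stronger inhibitor, a higher number a weaker inhibitor), compound 1 gives 8960 nM. Compound 2 `CCc1nc(-c2ccc(COc3cccc(C(=O)NO)c3)cc2)no1` carries a 5-ethyl-1,2,4-oxadiazol-3-yl instead, and in this assay compound 2 gives 34700 nM, the higher of the two numbers and thus the weaker inhibitor; the step of a 3.9-fold higher number from compound 1 to compound 2 (0.59 log units; beyond the scatter) lies beyond the usual scatter. Compound 3 `O=C(NO)c1cccc(OCc2ccc(-c3noc(CCc4ccccc4)n3)cc2)c1` keeps everything in compound 2 and adds one change: phenyl in place of hydrogen on a saturated chain carbon, two bonds along the chain from an aromatic carbon. Within the data shown here, no measured step repeats this kind of change; the only step available, a 3.9-fold higher number from compound 1 to compound 2 (0.59 log units; beyond the scatter), exchanged one ring for another at a different place and says little about going from ethyl to phenethyl on the chain. The expectation in this assay therefore leans only slightly toward a lower number, and a step of a 1.7-fold lower number from compound 2 to compound 3 (0.24 log units; within the scatter) is expected, with wide uncertainty. For compound 3 the estimated value in this assay is 20000 nM, within a range from 5000 nM to 80000 nM.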

Compound 3, half-maximal inhibitory concentration: 1730 nM
Compound 3: middle estimate off by 12-fold (1.06 log units), on the high side; the whole stated range lies above it.
By their numbers in this assay, from the lowest: compound 3; then compound 1; then compound 2.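

In this assay, phenyl in place of hydrogen on a saturated chain carbon, two bonds along the chain from an aromatic carbon, turns ethyl into phenethyl and gives a 20-fold lower number from compound 2 to compound 3 (1.30 log units; beyond the scatter). Among these compounds, the only earlier step, a 3.9-fold higher number from compound 1 to compound 2 (0.59 log units; beyond the scatter), ran the other way and was smaller, so the weak inhibition seen with the 5-ethyl-1,2,4-oxadiazol-3-yl group is not fixed by that ring alone: what is carried on the chain can change the number strongly, and here it lowers it well beyond the scatter. Nothing on hand explains how the added phenyl produces this drop, so the step stands as an observation without a cause.

The compounds shown leave open whether the phenyl ring itself is needed or whether a plain butyl chain in the same place would give a similar drop. Also open, on these data alone, is how the number would respond to a benzyl group, with a shorter link to the phenyl, to a chlorine on the new phenyl, or to an amine at the end of the chain.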